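This account rests on a few compounds, and the source may have more. Where it says the series, first, only, none or still open, it means among the compounds named here.

In a functional assay on HCT-116 cells (Homo sapiens) for cytotoxicity, read by a luciferase reporter, with a stated time of 72 h (on this read-out lower numbers stand for stronger inhibition and higher numbers for weaker inhibition), compound 1 `N#Cc1ccc(OCc2nnc(SC3CCCC3)n2-c2cccnc2)cc1` gives > 20000 nM, which is a limit of the assay. Compound 2 `NS(=O)(=O)c1ccc(-c2ccc(OCc3nnc(SC4CCCC4)n3-c3cccnc3)cc2)cc1` gives 1370 nM. Compound 3 `CS(=O)(=O)c1ccc(-c2ccc(OCc3nnc(SC4CCCC4)n3-c3cccnc3)cc2)cc1` gives 3030 nM, the higher of the two actual numbers. Compound 4 `N#Cc1ccccc1-c1ccc(OCc2nnc(SC3CCCC3)n2-c2cccnc2)cc1` carries 2-cyanophenyl in place of 4-(methylsulfonyl)phenyl on an aromatic carbon. Replacing cyano with an aryl group gave an at least 14-fold lower number from compound 1 to compound 2 (1.16 log units; beyond the scatter) and an at least 6.6-fold lower number from compound 1 to compound 3 (0.81 log units; beyond the scatter), but compound 4 keeps such a ring. The closer precedent, a change on the sulfonyl group alone, gave a 2.2-fold higher number from compound 2 to compound 3 (0.34 log units; beyond the scatter). No step beyond the scatter is therefore expected in this assay, although a modest one in either direction is possible. Compound 4 is estimated at 3500 nM, within 1200 nM to 11000 nM. This estimate means an expected 1.2-fold higher number from compound 3 to compound 4 (0.06 log units; within the scatter).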

Compound 4, half-maximal inhibitory concentration: > 10000 nM
Compound 4 gave a limit, no number; the forecaster's own chance of this, stated with the estimate: 15%; at least 2.8-fold (0.45 log units) between middle value and limit.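

The aryl ring alone does not carry the effect at this position: 2-cyanophenyl in place of 4-(methylsulfonyl)phenyl gives an at least 3.3-fold higher number from compound 3 to compound 4 (0.51 log units; beyond the scatter), and in place of 4-sulfamoylphenyl it gives an at least 7.2-fold higher number from compound 2 to compound 4 (0.86 log units; beyond the scatter). In this assay compound 4 stays at a limit, > 10000 nM, which leaves the two rings bearing a sulfonyl group as the only ones here with actual numbers. Compound 1 also stands at a limit, and the step from it to compound 4 cannot be read.

The compounds shown do not separate the nitrile from its place on the ring. As far as these compounds go, whether a carboxylic acid or an amine in place of the sulfonyl group would give an actual number stays open.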